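The compounds below may be only part of what the source reports. "The series", "measured", "known", "first", "only" and "open" are said of these compounds alone.

Measured so far in a physicochemical assay for solubility, with a stated time of 18 h, at pH 7.4 (on this read-out higher numbers stand for higher solubility and lower numbers for lower solubility), are two compounds:
Compound 1 `COc1cccc(CNCCCNc2ccnc3cc(CCC(C)C)ccc23)c1O` gives 4200 nM
Compound 2 `COc1cccc(CNCCCNc2ccnc3cc(-c4ccccc4)ccc23)c1O` gives 32000 nM

Compound 2 holds the higher number of the two. Compound 3 `COc1cccc(CNCCCNc2ccnc3cc(Cc4ccc(F)cc4Cl)ccc23)c1O` carries 2-chloro-4-fluorobenzyl in place of phenyl on an aromatic carbon and is not yet measured. Going by the values given here, the one measured step that bears on this is a 7.6-fold higher number from compound 1 to compound 2 (0.88 log units; beyond the scatter) with phenyl in place of isopentyl, a modest step beyond the scatter. Phenyl leaves here, so a step of like size toward a lower number is expected in this assay on that single step, and no measured compound carries the entering group. What is expected is a 3.6-fold lower number from compound 2 to compound 3 (0.55 log units; beyond the scatter) and not a rise. Compound 3 is estimated at 9000 nM with 2500 nM to 30000 nM as the expected range.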

Compound 3, solubility: 4200 nM
For compound 3 the middle estimate is 2.1-fold (0.33 log units) above the measured one; measured number inside the range.
By their numbers in this assay, from the lowest: compounds 1 and 3 (each within the scatter of the next); then compound 2.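

In this assay, 2-chloro-4-fluorobenzyl in place of phenyl on this aromatic carbon gives a 7.6-fold lower number from compound 2 to compound 3 (0.88 log units; beyond the scatter), so a six-membered aromatic ring in the group does not by itself keep the number of compound 2. Set against the isopentyl of compound 1, the same group gives no change at the digits printed from compound 1 to compound 3 (within the scatter), which leaves compound 2 alone apart from the other two. Nothing available here speaks to the cause of either step. The compounds shown do not separate the carbon link of the benzyl group from its chlorine and fluorine, as unsubstituted benzyl would. On these data alone, how an amine or a carboxylic acid on this aromatic carbon would read also stays open.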